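This account rests on a few compounds, and the source may have more. Where it says the series, first, only, none or still open, it means among the compounds named here.

Three uridine-like triphosphate and diphosphate compounds were tested in an in vitro functional assay on 1321-N1 cells for agonist activity at P2Y purinoceptor 6 (Homo sapiens); a higher number here means that more compound is needed for the effect, a lower number that less compound is needed. Compound 1 `Cn1c(=O)ccn([C@@H]2O[C@H](COP(=O)(O)OP(=O)(O)OP(=O)(O)O)[C@@H](O)[C@H]2O)c1=O` sits at the limit of this assay, at > 1000 nM, which is a limit of the assay and not a number. Compound 2 `O=c1[nH]c(=O)n([C@@H]2O[C@H](COP(=O)(O)OP(=O)(O)OP(=O)(O)O)[C@@H](O)[C@H]2O)cc1Br` gives 291 nM. Compound 3 `Cn1c(=O)ccn([C@@H]2O[C@H](COP(=O)(O)OP(=O)(O)O)[C@@H](O)[C@H]2O)c1=O` also sits at a limit, > 1000 nM. The change a group of 9 heavy atoms (4 carbon, 2 nitrogen, 2 oxygen, 1 bromine; one six-membered aromatic ring with 2 hetero atoms) in place of a group of 9 heavy atoms (5 carbon, 2 nitrogen, 2 oxygen; one six-membered aromatic ring with 2 hetero atoms), on a saturated ring carbon gave an at least 3.4-fold lower number from compound 1 to compound 2 (0.53 log units; beyond the scatter). The change a hydrogen atom in place of a group of 4 heavy atoms (3 oxygen, 1 phosphorus; no ring), on an oxygen gave a step that the two limits leave unreadable from compound 1 to compound 3, because both compounds sit at the limit of > 1000 nM in this assay, at which 2 of the 3 values shown sit. Compound 4 `O=c1[nH]c(=O)n([C@@H]2O[C@H](COP(=O)(O)OP(=O)(O)O)[C@@H](O)[C@H]2O)cc1Br` is not yet measured; it carries the same kind of change as compound 3, (a hydrogen atom in place of a group of 4 heavy atoms (3 oxygen, 1 phosphorus; no ring), on an oxygen), on the same place, while the two cores differ as described by a group of 9 heavy atoms (4 carbon, 2 nitrogen, 2 oxygen, 1 bromine; one six-membered aromatic ring with 2 hetero atoms) in place of a group of 9 heavy atoms (5 carbon, 2 nitrogen, 2 oxygen; one six-membered aromatic ring with 2 hetero atoms), on a saturated ring carbon. Since the step from compound 1 to compound 3 left no readable size, compound 4 is expected to stay close to compound 2, with an expected step of a 1.9-fold lower number from compound 2 to compound 4 (0.29 log units; within the scatter). Compound 4 is thus estimated at 150 nM, between 30 nM and 800 nM.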

Compound 4, half-maximal effective concentration: 151 nM
For compound 4 the middle estimate is 1.0-fold (0.00 log units) below the measured one, within the range that was stated.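

In this assay, putting a hydrogen atom in place of the group of 4 heavy atoms (3 oxygen, 1 phosphorus) on the oxygen gives a 1.9-fold lower number from compound 2 to compound 4 (0.28 log units; within the scatter), so on this core the two compounds cannot be told apart. This is one readable case, and it does not show that the change behaves alike on another core. The same change on the core of compound 1 cannot be read, because compound 1 and compound 3 both give only a limit and not a number: the limit of > 1000 nM in this assay, at which 2 of the 4 values shown sit.

From the compounds shown here alone, whether an amine or a carboxylic acid on that same oxygen would match compound 2 remains open. So does how the change would read on a core whose values are not limits, other than that of compound 2.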